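Aryl hydrazone exchange on the way from compound 2 to compound 3

The source may report more compounds than this note shows. Statements on the series, on what has been measured and on what is new or still open speak of the compounds shown alone.

Compound 1 `CN(C)CCn1cnnc1-c1cc(Oc2ccc(NC(=O)N/N=C/c3ccc(Cl)cc3Cl)cc2F)ccn1` in an ADME assay on WI-38 cells (Homo sapiens) for cytotoxicity, read by MTT assay, with a stated time of 72 h (a higher number here means a weaker inhibitor, a lower number a stronger inhibitor), gives 4760 nM. Compound 2 `CN(C)CCn1cnnc1-c1cc(Oc2ccc(NC(=O)N/N=C/c3ccc(O)c(F)c3)cc2F)ccn1` has no result in this assay: for compound 2 the entry reads "not determined" (no result reported), so compound 2 stands on no number of its own, and nothing can be said of how it compares with compound 1. Compound 3 `CN(C)CCn1cnnc1-c1cc(Oc2ccc(NC(=O)N/N=C/c3ccc(F)cc3Cl)cc2F)ccn1` is still to be measured in this assay. It differs from compound 2 in one place: 2-chloro-4-fluorophenyl in place of 3-fluoro-4-hydroxyphenyl on a carbon with a double bond to nitrogen. Within the data shown here, no step between two measured compounds exists in this set, so no measured step gives the size of the change from compound 2 to compound 3 in this assay, and with compound 2 unmeasured no direction can be stated either. The expectation for compound 3 therefore rests on a single measured number: in this assay compound 1 gives 4760 nM, and compound 1 differs from compound 3 only in the aryl group on the carbon with a double bond to nitrogen. Compound 3 is expected to land near that value, at about 5000 nM in this assay, within a wide range of 1500 nM to 16000 nM, a single supporting number allowing no tighter estimate.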

Compound 3, half-maximal inhibitory concentration: 2090 nM
The estimate for compound 3 lay 2.4-fold (0.38 log units) above the measured number, and the stated range covers the measured number.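

In this assay, fluoro in place of chloro on an aromatic carbon of the aryl group, on a carbon with a double bond to nitrogen, gives a 2.3-fold lower number from compound 1 to compound 3 (0.36 log units; beyond the scatter). Among these compounds, this is the first measured step and it shows that this position responds to a single halogen exchange, with the lower number marking compound 3 as the stronger inhibitor of the pair, though the step is only modest and rests on one pair of compounds. No measurement bears on the reason for this difference.

Going by these compounds, the step from compound 2 to compound 3 cannot be read, so the exchange of 3-fluoro-4-hydroxyphenyl for 2-chloro-4-fluorophenyl has neither a size nor a direction in this assay, and the effect of the hydroxyl group remains unknown. Also open, on these data alone, is how the number would move with an amine, a carboxylic acid or a methoxy group on this aryl ring, since the compounds with values carry only halogens there.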